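A few compounds are considered here, and "the series" means these few. Any claim that something is new, unique, unknown or untested is made for them only; others in the source may bear on it.

Compound 1 `O=C(O)/C=C/c1ccc2noc(-c3ccc(Oc4ccccc4)cc3)c2c1` gives 94 nM in an assay for inhibition of inositol hexakisphosphate kinase 2 (Homo sapiens), read by colorimetric assay, coupled enzyme assay and malachite green, with a stated time of 120 min, in the presence of a further agent that is not named here; on this read-out lower numbers stand for stronger inhibition and higher numbers for weaker inhibition.
Compound 2 `O=C(O)c1ccc2noc(-c3ccc(-c4cccnc4)cc3)c2c1` gives 54 nM in this assay.
Compound 3 `O=C(O)c1ccc2noc(-c3ccc(Cc4ccccc4)cc3)c2c1` gives 65 nM in this assay.

Among these three numbers, compound 3 stands second highest, and the other two lie within the scatter of it. Compound 4 `O=C(O)c1ccc2noc(-c3ccc(Oc4ccccc4)cc3)c2c1` differs from compound 3 by phenoxy in place of benzyl on an aromatic carbon. Within the data shown here, only one measured step touches this same position, a 1.2-fold higher number from compound 2 to compound 3 (0.08 log units; within the scatter), and it stayed within the scatter. Compound 1 carries the same phenoxy group on a different core and gives 94 nM, close to compound 3. In this assay compound 4 is therefore expected to show a 1.1-fold higher number from compound 3 to compound 4 (0.03 log units; within the scatter), no shift beyond the scatter. The estimate for compound 4 is 70 nM, with a range from 30 nM to 160 nM.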

Compound 4, half-maximal inhibitory concentration: 280 nM
Compound 4: middle estimate off by 4.0-fold (0.60 log units), on the low side; the whole stated range lies below it.
By their numbers in this assay, from the lowest: compounds 2, 3 and 1 (each within the scatter of the next); then compound 4.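

In this assay the group at this position does matter: phenoxy in place of benzyl gives a 4.3-fold higher number from compound 3 to compound 4 (0.63 log units; beyond the scatter) even though both groups hold the same count of heavy atoms and one six-membered aromatic ring. Phenoxy in place of pyridin-3-yl gives a 5.2-fold higher number from compound 2 to compound 4 (0.71 log units; beyond the scatter) and so sets phenoxy apart from both other groups, which lie within the scatter of each other. With phenoxy kept, carboxy in place of 2-carboxyethenyl gives a 3.0-fold higher number from compound 1 to compound 4 (0.47 log units; beyond the scatter) and shows that the other position counts too.

On these data alone, whether an amine link or a longer chain between the two rings would behave like benzyl or like phenoxy stays open. No measurement here accounts for the gap.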